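The source may hold more compounds than are shown below. What is called first, only, known or untested is meant among the compounds shown, and "the series" means these compounds.

Working notes on the series. The shared core of compound 1 `COc1cc(OC)c(/C=C/S(=O)(=O)Cc2ccc(Br)c([N+](=O)[O-])c2)c(OC)c1` is kept throughout, with changes confined to the benzyl ring on the sulfone side. In a functional assay on DU-145 cells (Homo sapiens) for cytotoxicity, read by trypan blue exclusion, with a stated time of 96 h (on this read-out lower numbers stand for stronger inhibition and higher numbers for weaker inhibition), compound 1 gives 25000 nM. Compound 2 `COc1cc(OC)c(/C=C/S(=O)(=O)Cc2ccc(Cl)c(N)c2)c(OC)c1` gives 10 nM in this assay. Compound 3 `COC(=O)C(F)(F)Nc1cc(CS(=O)(=O)/C=C/c2c(OC)cc(OC)cc2OC)ccc1OC` gives 250 nM in this assay, which places it second highest of the three numbers: its nearest neighbour is compound 2, whose number is lower by a margin beyond the scatter, and the furthest is compound 1, whose number is higher by a margin also beyond the scatter. None of these pairs differs at a single place, so nothing tighter than the raw numbers can be read from them.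

Compound 4 `COc1cc(OC)c(/C=C/S(=O)(=O)Cc2ccc(OC)c(NC(C(=O)O)c3ccc(Cl)cc3)c2)c(OC)c1` is not yet measured in this assay. It differs from compound 3 in one place: carboxy(4-chlorophenyl)methyl in place of difluoro(methoxycarbonyl)methyl on a nitrogen on an aromatic ring. The surroundings of that nitrogen and the rest of the core are unchanged. Going by the values given here, no measured pair isolates this change, so the expectation rests on the numbers of compound 2 and compound 3 alone, which show that substitution on this nitrogen sits higher than the free amine. A step of modest size upward is expected, a 2.0-fold higher number from compound 3 to compound 4 (0.30 log units; within the scatter), at or just beyond the edge of the scatter. Compound 4 is therefore estimated at 500 nM, within a range from 100 nM to 2500 nM.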

Compound 4, half-maximal inhibitory concentration: 400 nM
Compound 4: middle estimate off by 1.3-fold (0.10 log units), on the high side, and the stated range covers the measured number.
By their numbers in this assay, from the lowest: compound 2; then compounds 3 and 4 (each within the scatter of the next); then compound 1.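

In this assay, carboxy(4-chlorophenyl)methyl in place of difluoro(methoxycarbonyl)methyl on a nitrogen on an aromatic ring gives a 1.6-fold higher number from compound 3 to compound 4 (0.20 log units; within the scatter), so this pair cannot be told apart on this read-out. Going by these compounds alone, this is the first pair that differs in one place, and it shows that this nitrogen can carry either substituent without a separation beyond the scatter, even though the entering group has 11 heavy atoms, a six-membered aromatic ring and a hydrogen-bond donor, while the leaving group has 7 heavy atoms and no ring. No supporting measurement bears on why the two substituents read alike.

The compounds shown leave open how a free amine on this nitrogen would read with the rest of compound 3 unchanged, which would connect this pair to the much lower number of compound 2, a compound that differs from compound 3 in more than one place. Also open, from the compounds shown here alone, is whether the carboxylic acid or the chlorine of the entering group matters here, which a methyl ester or an unsubstituted phenyl ring in compound 4 would test.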